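Changing One Ring Group on Compound 2

A few compounds are considered here, and "the series" means these few. Any claim that something is new, unique, unknown or untested is made for them only; others in the source may bear on it.

Within the data shown here, in a functional assay on PANC-1 cells (Homo sapiens), read by microscopy, crystal violet staining and transwell migration, with a stated time of 18 h, in the presence of a further agent that is not named here (on this read-out lower numbers stand for stronger inhibition and higher numbers for weaker inhibition), compound 2 `CCc1nc(-c2ccc(OC(F)F)cc2)n(-c2cccc(C(=O)NCCCCc3ccccc3)c2)n1` gives 830 nM, the only actual number so far. In this assay, compound 1 `COc1ccc(-c2nc(C)nn2-c2cccc(C(=O)NCCCc3ccc(Cl)cc3)c2)cc1` gives > 20000 nM, which is a limit of the assay and not a number. The two compounds differ in more than one place, so their results do not isolate the effect of any single group.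

The next compound, compound 3 `CCc1nc(-c2cnc(OC)cn2)n(-c2cccc(C(=O)NCCCCc3ccccc3)c2)n1`, keeps the rest of compound 2 but carries 5-methoxypyrazin-2-yl in place of 4-(difluoromethoxy)phenyl on an aromatic carbon. Among the measured compounds shown here, no measured pair tests this swap, so the forecast is uncertain. A moderate weakening, beyond the usual scatter, is expected. The expected change is a 3.0-fold higher number from compound 2 to compound 3 (0.48 log units; beyond the scatter). For compound 3, the estimated value is 2500 nM, with an expected range from 600 nM to 12000 nM.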

Compound 3, half-maximal inhibitory concentration: 310 nM
Compound 3: the middle estimate sits 8.1-fold (0.91 log units) above what was measured, outside the stated range (below it).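

Among these compounds, this is the first comparison in this assay that changes only one place, and it gives a 2.7-fold lower number from compound 2 to compound 3 (0.43 log units; beyond the scatter), so stronger inhibition. At this ring carbon, the carbon-only ring of 4-(difluoromethoxy)phenyl is therefore not required: 5-methoxypyrazin-2-yl, with its two ring nitrogens, is better tolerated in this pair. Nothing measured here explains the gain.

The swap changes the ring and the group on it at once, and the compounds shown do not separate these two changes. Going by these compounds, it remains open how a 5-methoxypyridin-2-yl group, with one ring nitrogen, or a pyrazine ring carrying an amine in place of the methoxy would compare with compound 3.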